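Trimming the Side Group of Compound 1

A few compounds are considered here, and "the series" means these few. Any claim that something is new, unique, unknown or untested is made for them only; others in the source may bear on it.

Among the three compounds measured in an assay for inhibition of serine/threonine-protein kinase PAK 4 (Homo sapiens), read by FRET and Z'-LYTE, with a stated time of 60 min, tested at 5 uM, in the presence of a further agent that is not named here (a higher number here means a stronger effect of the compound at the concentration tested, a lower number a weaker effect), compound 1 `CC(C)C(=O)OCOC(=O)N1CCN(C(=O)c2nc(Nc3cc(C4CC4)[nH]n3)c3cc(Cl)ccc3n2)C[C@H]1C` stands highest: compound 1 gives 51.6%. Compound 2 `CC(OC(=O)N1CCN(C(=O)c2nc(Nc3cc(C4CC4)[nH]n3)c3cc(Cl)ccc3n2)C[C@H]1C)OC(=O)C(C)(C)C` gives 23.6%, and compound 3 `CCCCCOC(=O)N1CCN(C(=O)c2nc(Nc3cc(C4CC4)[nH]n3)c3cc(Cl)ccc3n2)C[C@H]1C` gives 12.6%. Both changes away from compound 1 lowered the number, a number 28 percentage points lower from compound 1 to compound 2 (beyond the scatter) and a number 39 percentage points lower from compound 1 to compound 3 (beyond the scatter), while between the two smaller values a number 11 percentage points lower from compound 2 to compound 3 (beyond the scatter). Compound 4 `CC(C)OC(=O)N1CCN(C(=O)c2nc(Nc3cc(C4CC4)[nH]n3)c3cc(Cl)ccc3n2)C[C@H]1C` differs from compound 1 in one place: isopropyl in place of ((isopropylcarbonyl)oxy)methyl on an oxygen next to a carbonyl group. This resembles the change leading to compound 3, where a plain chain likewise replaced the group of compound 1, and that step was the large one. A drop of comparable size is therefore expected: a number 33.6 percentage points lower from compound 1 to compound 4 (beyond the scatter). Compound 4 is estimated to give 18%, within a range from 5% to 35%.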

Compound 4, a percentage reported as inhibition, at one concentration (the size of the read-out at that concentration, not a potency): 75.8%
Estimate against measurement, compound 4: 57.8 percentage points below; measured number above the stated range.
By their numbers in this assay, from the lowest: compound 3; then compound 2; then compound 1; then compound 4.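

Swapping the group of compound 1 for a plain chain need not lower the number in this assay, since isopropyl on this oxygen gives a number 24.2 percentage points higher from compound 1 to compound 4 (beyond the scatter) and places compound 4 highest of the four. Which plain chain sits here clearly matters, with a number 63.2 percentage points higher from compound 3 to compound 4 (beyond the scatter) for isopropyl in place of pentyl, and the change also gives a number 52.2 percentage points higher from compound 2 to compound 4 (beyond the scatter) when methyl replaces ((tert-butyl)carbonyl)oxy. Nothing available explains these differences.

Going by these compounds, whether an ethyl, a propyl or a cyclopropyl group on this oxygen would keep the higher number remains open. So does the effect of a tert-butyl group or an amine at this place.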